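Methoxy for methyl: stomach inhibition at one dose

This account rests on a few compounds, and the source may have more. Where it says the series, first, only, none or still open, it means among the compounds named here.

Measured compounds:
compound 1 `COc1ccc(-c2cc(=O)c3cc(C(=O)O)ccc3o2)cc1`: 13%
compound 2 `Cc1ccc(-c2oc3ccc(C(=O)O)cc3c(=O)c2O)cc1`: 6%

In a functional assay on the whole organism (stomach) for inhibition, with Rattus norvegicus as the target, at a dose of 80 mg/kg (a lower number here means less inhibition, a higher number more inhibition at the dose given (going by the name of the read-out)), compound 1 gives 13%, and compound 2 gives 6%. Compound 2 has the lower of the two numbers, yet the gap to compound 1 lies within the scatter, so the two are not separated by this assay. Compound 3 `COc1ccc(-c2oc3ccc(C(=O)O)cc3c(=O)c2O)cc1` is compound 2 with methoxy in place of methyl on an aromatic carbon. Going by the values given here, no measured pair shows this change on its own, so the expected step of a number 4 percentage points higher from compound 2 to compound 3 (within the scatter) is none beyond the scatter. Compound 3 is thus estimated at 10%, with a range from 0% to 25%.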

Compound 3, a percentage reported as inhibition, in the whole organism at one dose (the size of the read-out at that dose, not a potency): 24%
Estimate against measurement, compound 3: 14 percentage points below, and the stated range covers the measured number.
By their numbers in this assay, from the lowest: compounds 2 and 1 (each within the scatter of the next); then compound 3.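

In this assay, methoxy in place of methyl on an aromatic carbon, para to a large group, now has a step of its own, a number 18 percentage points higher from compound 2 to compound 3 (beyond the scatter). Hydroxy in place of hydrogen on an aromatic carbon, with the methoxy group kept, gives a number 11 percentage points higher from compound 1 to compound 3 (beyond the scatter), so each single change moves the number beyond the scatter, which the earlier pair could not show. Nothing measured here bears on why the number moves.

The compounds shown leave open how an ethoxy group or an amine at that place would compare in this assay. Also open, as far as these compounds go, is whether the hydroxy step holds with methyl in place of methoxy.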